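A few compounds are considered here, and "the series" means these few. Any claim that something is new, unique, unknown or untested is made for them only; others in the source may bear on it.

Two compounds of this series carry numbers. Compound 1 `N=C(N)c1ccc(-c2ccc(-c3cncc4ccccc34)s2)s1` gives 240 nM in a functional assay on K562 cells (Homo sapiens) for inhibition, read by sulforhodamine B assay, with a stated time of 48 h; on this read-out lower numbers stand for stronger inhibition of growth and higher numbers for weaker inhibition of growth. Compound 2 `N=C(N)c1ccc(-c2ccc(-c3ccc(F)cc3)o2)o1` gives 490 nM in this assay, the highest of the two numbers; the nearest, compound 1, sits at a number that is lower beyond the scatter. Compound 3 `N=C(N)c1ccc(-c2ccc(-c3ccc(Cl)cc3)o2)o1` follows from compound 2 by the change (chloro in place of fluoro on an aromatic carbon), that is chloro in place of fluoro on an aromatic carbon. Among the measured compounds shown here, no measured pair shows such a step here. The step of a 1.2-fold lower number from compound 2 to compound 3 (0.09 log units; within the scatter) is expected to stay within the scatter, with no clear direction. Compound 3 is estimated at 400 nM, with a range from 150 nM to 1000 nM.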

Compound 3, concentration for 50% growth inhibition: 1370 nM
Compound 3: the middle estimate sits 3.4-fold (0.53 log units) below what was measured; the whole stated range lies below it.
By their numbers in this assay, from the lowest: compound 1; then compound 2; then compound 3.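

At the place on the six-membered aromatic ring para to a large group, the halogen matters in this assay: chloro in place of fluoro gives a 2.8-fold higher number from compound 2 to compound 3 (0.45 log units; beyond the scatter) and so weaker inhibition of growth. Among the compounds shown here, this is the only single-place step so far, and it shows that this position does not tolerate every halogen equally. Nothing available bears on the reason for this step.

As far as these compounds go, whether an amine, a methoxy group or plain hydrogen at this place would follow fluoro or chloro remains open. From the compounds shown here alone, whether the same step holds on the core of compound 1 also remains open.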